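This account rests on a few compounds, and the source may have more. Where it says the series, first, only, none or still open, it means among the compounds named here.

Measured compounds:
compound 1 `O=C(Nc1ccccc1C(F)(F)F)C1CCc2ccccc2N1` — 57600 nM
compound 2 `O=C(Nc1ccccc1C(F)(F)F)C1CCc2ccccc2N1C(=O)c1ccccc1` — 8090 nM

Both numbers come from a functional assay on ACHN cells (Homo sapiens) for cytotoxicity, read by sulforhodamine B assay, with a stated time of 72 h; on this read-out higher numbers stand for weaker inhibition of growth and lower numbers for stronger inhibition of growth. Among the measured compounds shown here, compound 2 holds the lower of the two, and the single step between them is a 7.1-fold lower number from compound 1 to compound 2 (0.85 log units; beyond the scatter), the benzoyl on the ring nitrogen. Compound 3 `O=C(Nc1ccccc1C(F)(F)F)C1CCc2ccccc2N1C(=O)c1ccccc1Cl` differs from compound 2 by chloro in place of hydrogen on an aromatic carbon. For the measured compounds named here, no measured step touches the benzoyl ring itself, so the data give no direction for this change. The expected step of a 1.2-fold lower number from compound 2 to compound 3 (0.10 log units; within the scatter) is therefore small, within the usual scatter. Compound 3 is estimated at 6500 nM in this assay, with a range from 2500 nM to 20000 nM.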

Compound 3, concentration for 50% growth inhibition: 3900 nM
Beside the measured number, compound 3's estimate is 1.7-fold (0.22 log units) above it; measured number inside the range.
By their numbers in this assay, from the lowest: compound 3; then compound 2; then compound 1.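

In this assay, among the compounds shown here, the benzoyl ring itself responds to substitution: chloro on an aromatic carbon, ortho to a large group, gives a 2.1-fold lower number from compound 2 to compound 3 (0.32 log units; beyond the scatter), the first measured step on this ring and modest in size. With (2-chlorophenyl)carbonyl in place of hydrogen on the nitrogen, the change from the unacylated compound is a 15-fold lower number from compound 1 to compound 3 (1.17 log units; beyond the scatter), larger than the step for benzoyl alone. Nothing available explains the effect of chloro. Still open, going by these compounds, are the other carbons of this ring, and whether a methoxy group, an amine or a carboxylic acid would do the same in place of chloro.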